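The compounds below may be only part of what the source reports. "The series", "measured", "known", "first", "only" and "open" are said of these compounds alone.

Measured so far:
Compound 1 `O=C(Nc1cccnc1)c1ccccc1OCc1cc(Cl)ccc1Cl` gives 990 nM in an assay on lysate for inhibition of phosphatidylcholine:ceramide cholinephosphotransferase 2 (Homo sapiens), read by HPLC, with stated times of 30 min and 2 h; a lower number here means a stronger inhibitor, a higher number a weaker inhibitor.
Compound 2 `O=C(Nc1cccnc1)c1ccccc1OCc1cccc(Cl)c1F` gives 3100 nM in this assay.

Among the compounds with values here, compound 2 stands highest of the two numbers; its one step, a 3.1-fold higher number from compound 1 to compound 2 (0.50 log units; beyond the scatter), lies beyond the scatter. Compound 3 `Cc1ccc(Cl)cc1COc1ccccc1C(=O)Nc1cccnc1` is not yet measured and differs from compound 2 by 5-chloro-2-methylphenyl in place of 3-chloro-2-fluorophenyl on a saturated chain carbon bound to an oxygen on an aromatic ring. Only a 3.1-fold higher number from compound 1 to compound 2 (0.50 log units; beyond the scatter) bears on this change, and it shows a modest shift from swapping the ring on the saturated chain carbon. The 5-chloro-2-methylphenyl of compound 3 resembles the 2,5-dichlorophenyl of compound 1 more closely than the 3-chloro-2-fluorophenyl does, and compound 1 gives 990 nM. A modest drop toward that figure is therefore expected for compound 3, a 2.4-fold lower number from compound 2 to compound 3 (0.38 log units; beyond the scatter). Compound 3 is estimated at 1300 nM, range 500 nM to 3500 nM.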

Compound 3, half-maximal inhibitory concentration: 1100 nM
The estimate for compound 3 lay 1.2-fold (0.07 log units) above the measured number, and the stated range covers the measured number.
By their numbers in this assay, from the lowest: compounds 1 and 3 (each within the scatter of the next); then compound 2.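

In this assay there is a 1.1-fold higher number from compound 1 to compound 3 (0.05 log units; within the scatter) for methyl in place of chloro on an aromatic carbon, so the two groups cannot be told apart on this ring. The change from 3-chloro-2-fluorophenyl to 5-chloro-2-methylphenyl gives a 2.8-fold lower number from compound 2 to compound 3 (0.45 log units; beyond the scatter) and leaves compound 2 alone with the highest of the three numbers. As far as these compounds go, whether a methoxy, an amine or a trifluoromethyl in place of that methyl would hold the number stays open, as does the outcome of losing the chloro altogether. Nothing at hand gives a reason for either step.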